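The compounds below may be only part of what the source reports. "The series", "measured", "known", "first", "only" and "open" are said of these compounds alone.

Compound 3, `CCN1C(=O)CSC1c1cccc(C(=O)NCCCCc2ccccc2)c1`, has been tested in a functional assay on SJSA-1 cells (Homo sapiens) for inhibition, read by CCK-8 assay, with a stated time of 72 h, tested at 1 uM (a higher number here means more inhibition at the concentration tested (going by the name of the read-out), a lower number less inhibition), where compound 3 gives 3%. Among the three compounds measured so far this is the second highest number, though the gap downwards is small: compound 1, `COc1ccccc1N1C(=O)CSC1c1cc(F)cc(C(=O)O)c1`, gives 0% in this assay, a value within the usual scatter of that of compound 3, so the two cannot be told apart. Going by the values given here, compound 2, `O=C(NCCCCc1ccccc1)c1cccc(C2SCC(=O)N2c2cccc(F)c2)c1`, gives 80%, and here the gap is real: the step of a number 77 percentage points lower from compound 2 to compound 3 (beyond the scatter) is the only single-change comparison that involves compound 3.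

Compound 4, `COc1ccc(F)cc1N1C(=O)CSC1c1cccc(C(=O)NCCCCc2ccccc2)c1`, differs from compound 3 at exactly the place that this step concerns: 5-fluoro-2-methoxyphenyl in place of ethyl on an amide-type nitrogen in a ring. Since swapping an aromatic ring for ethyl on the amide-type nitrogen in the ring cost compound 3 most of the inhibition seen for compound 2, putting an aromatic ring back in that position is expected to recover a large part of it. The expected step of a number 47 percentage points higher from compound 3 to compound 4 (beyond the scatter) is therefore upward and well beyond the scatter. Caution comes from compound 1, which also carries a methoxy-bearing aromatic ring on that nitrogen yet gives only 0%; however, compound 1 differs from compound 4 in two places, so its value cannot be read as a step. For compound 4, the estimate in this assay is 50%, with a range from 10% to 85%.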

Compound 4, a percentage reported as inhibition, at one concentration (the size of the read-out at that concentration, not a potency): 76%
Beside the measured number, compound 4's estimate is 26 percentage points below it, and the stated range covers the measured number.
By their numbers in this assay, from the lowest: compounds 1 and 3 (each within the scatter of the next); then compounds 4 and 2 (each within the scatter of the next).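

Putting 5-fluoro-2-methoxyphenyl on the amide-type nitrogen in place of ethyl gives a number 73 percentage points higher from compound 3 to compound 4 (beyond the scatter) in this assay. Compound 3 had shown only that inhibition was lost when ethyl replaced 3-fluorophenyl, and this reverse change shows that a second substituted phenyl group at this position also goes with high inhibition, so the result does not depend on the exact group in compound 2. Methoxy in place of hydrogen on an aromatic carbon of that ring gives a number 4 percentage points lower from compound 2 to compound 4 (within the scatter), so compound 2 and compound 4 cannot be told apart, and this position accepts the added methoxy without a measurable change in this read-out. Nothing available explains why ethyl and these aromatic groups differ so sharply.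

The compounds shown leave open whether the aromatic ring itself matters, since a cyclohexyl ring or a longer chain such as hexyl on the same nitrogen would be needed to separate ring type from group size. They also leave open how plain phenyl or a pyridine ring would behave there, and a single-concentration percentage cannot show whether compound 2 and compound 4 differ in potency.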